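Hydroxyethyl to hydroxymethyl on the amino acid side chain

A few compounds are considered here, and "the series" means these few. Any claim that something is new, unique, unknown or untested is made for them only; others in the source may bear on it.

Measured in an ADME assay on KB cells (Homo sapiens) for cytotoxicity, with a stated time of 48 h; on this read-out lower numbers stand for stronger inhibition and higher numbers for weaker inhibition 
- compound 1 `CC1=CCC[C@](C)(CC/C(C)=C/CC2=C(O)C(=O)C=C(N[C@@H](C(=O)O)[C@@H](C)O)C2=O)[C@@H]1C` (> 10 ug/mL) a limit
- compound 2 `C=C1[C@H](C)CCC[C@]1(C)CC/C(C)=C/CC1=C(O)C(=O)C=C(N[C@H](C(=O)O)[C@@H](C)O)C1=O` (> 10 ug/mL) a limit
- compound 3 `CC1=CCC[C@H]2[C@](C)(CC3=C(O)C(=O)C=C(N[C@@H](CO)C(=O)O)C3=O)[C@@H](C)CC[C@]12C` (7.6 ug/mL) a number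

The picture so far is (the limit of > 10 ug/mL in this assay, at which 2 of the 3 values shown sit). Compound 2 stands at (> 10 ug/mL), which is a limit and not a number.

Compound 4 `C=C1[C@H](C)CCC[C@]1(C)CC/C(C)=C/CC1=C(O)C(=O)C=C(N[C@@H](CO)C(=O)O)C1=O` is still to be measured. Its structural change is (hydrogen in place of methyl on a saturated chain carbon bound to an oxygen on a saturated carbon and a saturated chain carbon), that is, hydrogen in place of methyl on a saturated chain carbon bound to an oxygen on a saturated carbon and a saturated chain carbon. The same difference reads 1-hydroxyethyl to hydroxymethyl.

For the measured compounds named here, no measured step covers this change, so its size rests on judgement alone. Going by the values given here, the only numeric reading comes from compound 3 (7.6 ug/mL). The expected a number no higher from compound 2 to compound 4 (the limit leaves the size open) is small, with no direction beyond the scatter expected in this assay and a reading at the limit quite possible. For compound 4 the estimated value is (10 ug/mL), with an expected range from 5 ug/mL to 20 ug/mL as its bounds.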

Compound 4, half-maximal inhibitory concentration: > 10 ug/mL
Compound 4 gave a limit, no number (the forecaster's own chance of this, stated with the estimate: 55%); the middle value lies on the limit itself.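

For the compounds shown here, compound 2 and compound 4 both end at a limit rather than a number in this assay, so no step between them can be read. The compounds shown leave open whether 1-hydroxyethyl to hydroxymethyl changes the read-out in this pair at all: the limit of > 10 ug/mL in this assay, at which 3 of the 4 values shown sit.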